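The source may report more compounds than this note shows. Statements on the series, on what has been measured and on what is new or still open speak of the compounds shown alone.

In a functional assay on SW 1116 cells (Homo sapiens) for cytotoxicity, read by MTT assay, with a stated time of 48 h (a lower number here means a stronger inhibitor, a higher number a weaker inhibitor), the three measured compounds are:

compound 1 `O=C(CSc1nnc(-c2ccncc2)o1)N/N=C/c1ccccc1`, which gives 16700 nM
compound 2 `O=C(CSc1nnc(-c2ccncc2)o1)N/N=C/c1ccc(O)cc1`, which gives 12200 nM
compound 3 `Cc1ccc(/C=N/NC(=O)CSc2nnc(-c3ccncc3)o2)cc1`, which gives 16800 nM

All three share the same core and differ only in the ring attached to the carbon with a double bond to nitrogen. Compound 3 sits among them with no separation: the step of a 1.0-fold higher number from compound 1 to compound 3 (0.00 log units; within the scatter) and the step of a 1.4-fold higher number from compound 2 to compound 3 (0.14 log units; within the scatter) are both within the scatter, so the three numbers cannot be told apart.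

Compound 4 `O=C(CSc1nnc(-c2ccncc2)o1)N/N=C/c1ccccc1O` is not yet measured. Its change from compound 3 is 2-hydroxyphenyl in place of 4-methylphenyl on a carbon with a double bond to nitrogen. For the measured compounds named here, the steps that bear on it are a 1.4-fold lower number from compound 1 to compound 2 (0.14 log units; within the scatter), which adds a hydroxy to that ring, and a 1.4-fold higher number from compound 2 to compound 3 (0.14 log units; within the scatter), which swaps hydroxy for methyl; neither moved the number beyond the scatter. Moving the hydroxy to another carbon of the same ring is untested here, and no step is shown for it. The expectation is therefore a step of a 1.1-fold lower number from compound 3 to compound 4 (0.05 log units; within the scatter), no larger than the scatter. Compound 4 is estimated at 15000 nM, between 7000 nM and 35000 nM.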

Compound 4, half-maximal inhibitory concentration: 7380 nM
Estimate against measurement, compound 4: 2.0-fold (0.31 log units) above, within the range that was stated.
By their numbers in this assay, from the lowest: compounds 4, 2, 1 and 3 (each within the scatter of the next, the first and the last beyond it).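

In this assay, the ring on the carbon with a double bond to nitrogen now gives its first steps beyond the scatter, both modest: a 2.3-fold lower number from compound 3 to compound 4 (0.36 log units; beyond the scatter) and a 2.3-fold lower number from compound 1 to compound 4 (0.35 log units; beyond the scatter). The two hydroxy compounds still cannot be separated, as a 1.7-fold lower number from compound 2 to compound 4 (0.22 log units; within the scatter) stays within the scatter, so moving the hydroxy from 4-hydroxyphenyl to 2-hydroxyphenyl has no demonstrated effect on its own. Nothing given here explains why 2-hydroxyphenyl stands apart from 4-methylphenyl or from the plain phenyl ring.

Still open, as far as these compounds go, is whether a methoxy or an amine in place of the hydroxy in 2-hydroxyphenyl would give a similar step. Also open, from the compounds shown here alone, is whether a carboxylic acid on this ring, or a pyridine ring in its place, would move the number further.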